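A few compounds are considered here, and "the series" means these few. Any claim that something is new, unique, unknown or untested is made for them only; others in the source may bear on it.

In a functional assay on MC-38 cells (Mus musculus) for antiproliferative activity, read by CCK-8 assay, with a stated time of 48 h (on this read-out higher numbers stand for weaker inhibition and lower numbers for stronger inhibition), compound 1 `COc1ccc(/C=C\c2cc(OC)c(OC)c(OC)c2)cc1OCc1ccc(CN2CCCC[C@H]2C(=O)O)cc1` reports only a limit of > 10000 nM and no number. Compound 2 `COc1ccc(/C=C\c2cc(OC)c(OC)c(OC)c2)cc1OCc1ccc(CN2CCCC[C@@H]2C(=O)O)cc1` likewise reports only a limit of > 10000 nM and no number. For the measured compounds named here, compound 3 `COc1ccc(/C=C\c2cc(OC)c(OC)c(OC)c2)cc1OCc1ccc(CNCCN(C)C)cc1` gives 1400 nM as the only true number so far. The change to compound 4 `COc1ccc(/C=C\c2cc(OC)c(OC)c(OC)c2)cc1OCc1ccc(CNCCNC(C)=O)cc1` is acetamido in place of dimethylamino on a saturated chain carbon, two bonds along the chain from an amine nitrogen and nothing else. Both an at least 7.1-fold lower number from compound 1 to compound 3 (0.85 log units; beyond the scatter) and an at least 7.1-fold lower number from compound 2 to compound 3 (0.85 log units; beyond the scatter) bear on it, yet each brought in the whole (2-(dimethylamino)ethyl)amino group and so guides only loosely. In this assay a small rise in the number, no larger than the scatter, is expected. The estimate is a 1.8-fold higher number from compound 3 to compound 4 (0.25 log units; within the scatter) for this step. Compound 4 is expected at 2500 nM with an estimated range of 700 nM to 9000 nM in this test.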

Compound 4, half-maximal inhibitory concentration: 1800 nM
Compound 4: middle estimate off by 1.4-fold (0.14 log units), on the high side, within the range that was stated.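

In this assay, putting acetamido in place of dimethylamino at this chain end gives a 1.3-fold higher number from compound 3 to compound 4 (0.11 log units; within the scatter), so the two groups cannot be told apart here, although only dimethylamino had been seen at this place before. The second chain also stands clear of the 2-carboxypiperidin-1-yl compounds, with an at least 5.5-fold lower number from compound 2 to compound 4 (0.74 log units; beyond the scatter) and an at least 5.5-fold lower number from compound 1 to compound 4 (0.74 log units; beyond the scatter).

As far as these compounds go, the true size of those two steps stays open, because both start from a limit and not a number: the limit of > 10000 nM in this assay, at which 2 of the 4 values shown sit. Whether a longer chain or a carboxylic acid at this chain end would behave alike also stays open.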